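The source may report more compounds than this note shows. Statements on the series, on what has been measured and on what is new or still open speak of the compounds shown alone.

Two compounds on the shared core come first. In a functional assay on HCT-116 cells (Homo sapiens) for inhibition, read by MTT assay, with a stated time of 48 h (a higher number here means a weaker inhibitor, a lower number a stronger inhibitor), compound 1 (`O=S(=O)(c1ccccc1)c1c(OCCCCCCO)no[n+]1[O-]`) has the entry "not determined" (no result reported) and so gives nothing to compare. Going by the values given here, compound 2 (`O=C(COCCOc1no[n+]([O-])c1S(=O)(=O)c1ccccc1)NO`) gives 13400 nM and holds the only number available, so it can be ranked against no other compound. Compound 3 (`CC(C)(COc1no[n+]([O-])c1S(=O)(=O)c1ccccc1)C(=O)NO`) has yet to be measured. Its structure departs from that of compound 2 in one place (1-(hydroxycarbamoyl)-1-methylethyl in place of ((hydroxycarbamoyl)methoxy)methyl on a saturated chain carbon bound to an oxygen on an aromatic ring): 1-(hydroxycarbamoyl)-1-methylethyl stands in place of ((hydroxycarbamoyl)methoxy)methyl on a saturated chain carbon bound to an oxygen on an aromatic ring. Among the compounds with values here, no measured step shows what a change of this kind does, so the expectation rests on a single anchor. With compound 2 at 13400 nM as that anchor, no step beyond the usual scatter of this assay is expected, in either direction. The estimated change is a 1.1-fold lower number from compound 2 to compound 3 (0.05 log units; within the scatter) and it should be read as no real shift. Compound 3 is expected at about 12000 nM with an estimated range from 3500 nM to 40000 nM as the likely span of its result.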

Compound 3, half-maximal inhibitory concentration: 9740 nM
Estimate against measurement, compound 3: 1.2-fold (0.09 log units) above, and the stated range covers the measured number.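

In this assay, 1-(hydroxycarbamoyl)-1-methylethyl in place of ((hydroxycarbamoyl)methoxy)methyl on a saturated chain carbon bound to an oxygen on an aromatic ring gives a 1.4-fold lower number from compound 2 to compound 3 (0.14 log units; within the scatter), so the two compounds cannot be told apart. Going by these compounds alone, this is the first measured step at this position, and it shows that, in this one pair, a group of 4 carbon and 2 oxygen atoms and one of 3 carbon and 3 oxygen atoms, each with 7 heavy atoms in all and each carrying the hydroxycarbamoyl unit, give numbers that lie within the scatter of each other. Nothing available bears on why the two numbers stand so close.

Going by these compounds, both measured compounds carry the hydroxycarbamoyl unit, so what a carboxylic acid or an amine at that end of the chain would do remains open. A longer chain between the hydroxycarbamoyl unit and the oxygen on the aromatic ring is also untested among the compounds shown, and a single step cannot say whether the position tolerates larger changes than this one.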